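Replacing Diisopropylamino on the Shared Core

The source may report more compounds than this note shows. Statements on the series, on what has been measured and on what is new or still open speak of the compounds shown alone.

In a functional assay on HL-60 cells (Homo sapiens) for inhibition, read by MTT assay, with a stated time of 48 h, tested at 10 uM (a lower number here means less inhibition of growth, a higher number more inhibition of growth at the concentration tested), compound 3 (`Cc1cc(=O)c2c(O)c(CN(C(C)C)C(C)C)c(O)c([C@H]3CCN(C)C[C@H]3O)c2o1`) gives 21%, the lowest of three values, against 38% for compound 2 (`Cc1cc(=O)c2c(O)c(CN3CCCC3)c(O)c([C@H]3CCN(C)C[C@H]3O)c2o1`) and 47% for compound 1 (`CCN(CC)Cc1c(O)c([C@H]2CCN(C)C[C@H]2O)c2oc(C)cc(=O)c2c1O`). Compound 4 (`Cc1cc(=O)c2c(O)c(CN3CC(O)CC3C(=O)O)c(O)c([C@H]3CCN(C)C[C@H]3O)c2o1`) carries 2-carboxy-4-hydroxypyrrolidin-1-yl in place of diisopropylamino on a saturated chain carbon bound to an aromatic carbon. The nearest measured precedents are the steps with the same leaving group's arrival: a number 17 percentage points lower from compound 2 to compound 3 (beyond the scatter) and a number 26 percentage points lower from compound 1 to compound 3 (beyond the scatter). For the measured compounds named here, compound 2 has the closest group, but no measured compound carries the carboxy or hydroxy substituents, so only a small rise is expected in this assay, likely none beyond the scatter. The expected change is a number 9 percentage points higher from compound 3 to compound 4 (within the scatter). For compound 4 the estimated value is 30%, with an expected range of 10% to 50%.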

Compound 4, percent growth inhibition at one concentration: 28%
Beside the measured number, compound 4's estimate is 2 percentage points above it, within the range that was stated.
By their numbers in this assay, from the lowest: compounds 3, 4, 2 and 1 (each within the scatter of the next, the first and the last beyond it).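

For the compounds shown here, with 2-carboxy-4-hydroxypyrrolidin-1-yl, oxygen-bearing substituents appear on the amine ring at this place for the first time, and in this assay there is a number 7 percentage points higher from compound 3 to compound 4 (within the scatter) and a number 10 percentage points lower from compound 2 to compound 4 (within the scatter). Compound 4 therefore cannot be separated from compound 3 or compound 2, while there is a number 19 percentage points lower from compound 1 to compound 4 (beyond the scatter). No evidence at hand explains these numbers. The compounds shown leave open how a pyrrolidine ring carrying only the carboxylic acid or only the hydroxyl would read. They also leave open how morpholin-4-yl would read on this saturated chain carbon bound to an aromatic carbon.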